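The source may hold more compounds than are shown below. What is called first, only, known or untested is meant among the compounds shown, and "the series" means these compounds.

Measured compounds:
compound 1, `Cn1c(-c2ccccc2)cnc1NC(=O)c1ccccc1` — in a toxicity assay on THP-1 cells (Homo sapiens) for inhibition (on this read-out lower numbers stand for higher toxicity in this test and higher numbers for lower toxicity in this test), compound 1 gives > 100000 nM, a limit of the assay.
compound 2, `COc1ccc(-c2cnc(NC(=O)c3ccccc3)n2C)cc1` — in this assay compound 2 gives > 100000 nM, also a limit of the assay.
Not yet measured: compound 3, `Cn1c(-c2ccccc2)cnc1NC(=O)c1ncc[nH]1`.

Among the measured compounds shown here, compound 1 stands only at a limit in this assay: no number is known for it, and the one further value shown is a limit as well. The change from compound 1 to compound 2 is methoxy in place of hydrogen on an aromatic carbon, with the step that the two limits leave unreadable from compound 1 to compound 2. Both values sit at the limit of > 100000 nM in this assay, at which 2 of the 2 values shown sit, so no step size can be read from this pair.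

The change to compound 3 is 1H-imidazol-2-yl in place of phenyl on a carbonyl carbon. For the measured compounds named here, no measured step touches the carbonyl carbon, and the one measured pair gives no guidance on direction or size in this assay. Compound 3 is expected to stay in the same region, so the estimated step is a number no higher from compound 1 to compound 3 (the limit leaves the size open). Compound 3 is estimated at 100000 nM, in the range 30000 nM to 300000 nM, most likely again reported only as a limit.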

Compound 3, half-maximal cytotoxic concentration: > 100000 nM
Compound 3 was reported as a limit; the forecaster's own chance of this, stated with the estimate: 75%; the middle value lies on the limit itself.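

No step can be read from compound 1 to compound 3, as both values are limits of the assay: the limit of > 100000 nM in this assay, at which 3 of the 3 values shown sit.

The compounds shown leave open how compound 1, compound 2 and compound 3 truly compare, and whether any change to the shared core gives a measurable value.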